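Cyclopentyl for phenyl on the saturated ring carbon

The source may report more compounds than this note shows. Statements on the series, on what has been measured and on what is new or still open speak of the compounds shown alone.

Measured so far:
compound 1 `CCOC(=O)C1=C(C)N/C(=N\C#N)NC1c1ccccc1`: 18%
compound 2 `CC1=C(C(=O)OC(C)C)C(C2CCCC2)NC(=O)N1`: 1%
compound 3 `CC1=C(C(=O)OC(C)C)C(c2ccccc2)NC(=O)N1`: 2%

In an assay on cells for displacement of a labelled ligand from adenosine receptor A1 (Homo sapiens), with a stated time of 60 min, tested at 1 uM (a higher number here means more inhibition at the concentration tested (going by the name of the read-out), a lower number less inhibition), compound 1 gives 18%, the highest of the three numbers, beyond the scatter from both others. Compound 3 gives 2% and compound 2 gives 1%; these two lie within the scatter of each other. Compound 3 and compound 2 differ in one place, (cyclopentyl in place of phenyl on a saturated ring carbon), and the step is a number 1 percentage points lower from compound 3 to compound 2 (within the scatter).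

Compound 4 `CCOC(=O)C1=C(C)N/C(=N\C#N)NC1C1CCCC1` is not yet measured. It differs from compound 1 by cyclopentyl in place of phenyl on a saturated ring carbon, the same kind of change as from compound 3 to compound 2, not the same: in compound 1 the saturated ring carbon is next to the ring atom that bears an ethoxycarbonyl group, in compound 3 next to the ring atom that bears an isopropoxycarbonyl group. How the core of compound 1 differs from that of compound 3 is not broken down here.

For compound 4 the expected step is a number 3 percentage points lower from compound 1 to compound 4 (within the scatter), set beside a number 1 percentage points lower from compound 3 to compound 2 (within the scatter), which rests on that earlier step lying within the scatter; the higher starting number of compound 1 leaves more room for a change, so the range is kept wide. The estimate for compound 4 is 15%, expected between 2% and 30%.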

Compound 4, a percentage reported as inhibition, at one concentration (the size of the read-out at that concentration, not a potency): 11%
For compound 4 the middle estimate is 4 percentage points above the measured one; the measured number falls inside the stated range.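

In this assay, cyclopentyl in place of phenyl on a saturated ring carbon gives a number 7 percentage points lower from compound 1 to compound 4 (within the scatter). Set beside the same change on the other core, this step shows no difference that can be told apart: the same change on two cores in this assay, a number 1 percentage points lower (within the scatter) from compound 3 to compound 2 and a number 7 percentage points lower (within the scatter) from compound 1 to compound 4, 6 percentage points apart, within the scatter of two such steps So on these two cores the change can be carried across without a detectable difference, and on neither does it move the number beyond the scatter, but two pairs do not show that the step is the same on every core of the series or that it is truly absent, and a reading at one concentration says nothing about potency.

Still open, from the compounds shown here alone, is whether a carbon chain longer than these rings, or a ring carrying an amine or a carboxylic acid, on the saturated ring carbon would keep the number where it stands. Also open, going by these compounds, is how much of the gap between the two cores belongs to the ethoxycarbonyl group and how much to the rest of the core.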